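Adding chloro to compound 1

A few compounds are considered here, and "the series" means these few. Any claim that something is new, unique, unknown or untested is made for them only; others in the source may bear on it.

compound 1 `CC(C)(C)C(=O)Oc1c(Oc2ccccc2)c(Oc2ccccc2)c(OC(=O)C(C)(C)C)c2ccccc12` gives 7.8
compound 2 `CCCC(=O)Oc1c(Oc2ccccc2)c(Oc2ccccc2)c(OC(=O)CCC)c2cc(Cl)ccc12` gives 7.7

Going by the values given here, in a physicochemical assay for lipophilicity (a higher number here means a more lipophilic compound, a lower number a more polar compound), compound 1 at 7.8 and compound 2 at 7.7 lie within the scatter of each other, so compound 1 stands level with the only other measured compound. Compound 3 `CC(C)(C)C(=O)Oc1c(Oc2ccccc2)c(Oc2ccccc2)c(OC(=O)C(C)(C)C)c2cc(Cl)ccc12` differs from compound 1 by one change chloro in place of hydrogen on an aromatic carbon that is chloro in place of hydrogen on an aromatic carbon. Among the compounds with values here, no measured pair shows this change alone. An upward step in this assay beyond the scatter is expected. The estimated step of a number 0.60 log units higher from compound 1 to compound 3 (beyond the scatter) is moderate in size. For compound 3 the estimate is 8.4 with an expected range from 8 to 8.8 for a measurement.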

Compound 3, partition coefficient: 8.7
For compound 3 the middle estimate is 0.30 log units below the measured one; low and high end bracket the measured number.
By their numbers in this assay, from the lowest: compounds 2 and 1 (each within the scatter of the next); then compound 3.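

In this assay, chloro in place of hydrogen on an aromatic carbon, meta to a fused ring and para to a fused ring, gives a number 0.90 log units higher from compound 1 to compound 3 (beyond the scatter). Going by these compounds alone, this pair isolates the change for the first time, and the step lies beyond the scatter. Nothing at hand bears on what underlies the size of this step. This single pair covers one position and one substituent in one setting of the shared core. From the compounds shown here alone, whether fluoro, bromo or an amine at this position would give a similar step remains open.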